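Series notes: fluoropyridinyl for fluorophenyl on the ring amide nitrogen

The source may report more compounds than this note shows. Statements on the series, on what has been measured and on what is new or still open speak of the compounds shown alone.

Compound 3 `O=C(O)c1cccc(-c2ccc(/C=C3\S/C(=N\c4ccccc4)N(c4ccc(F)cc4)C3=O)s2)c1` in an ADME assay on Vero cells (Chlorocebus sabaeus) for cytotoxicity (on this read-out lower numbers stand for higher toxicity in this test and higher numbers for lower toxicity in this test), gives > 200000 nM, which is a limit of the assay and not a number. Compound 1 `O=C(O)c1cccc(-c2ccc(/C=C3\S/C(=N\c4ccc(F)cc4)N(c4ccc(F)cc4)C3=O)s2)c1` in this assay gives > 200000 nM, again a limit. Compound 2 `O=C(O)c1cccc(-c2ccc(/C=C3\S/C(=N\c4ccccc4)N(c4ccc(Cl)cc4)C3=O)s2)c1` in this assay gives > 200000 nM, also a limit. The step that the two limits leave unreadable from compound 1 to compound 3 therefore has no readable size, and the same holds for a step that the two limits leave unreadable from compound 2 to compound 3. On the numbers shown, compound 3 stands where every measured member of the series stands: at the limit of > 200000 nM in this assay, at which 3 of the 3 values shown sit, with no compound separated from it by a readable step.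

Compound 4 `O=C(O)c1cccc(-c2ccc(/C=C3\S/C(=N\c4ccccc4)N(c4ccc(F)cn4)C3=O)s2)c1` differs from compound 3 by 5-fluoropyridin-2-yl in place of 4-fluorophenyl on an amide-type nitrogen in a ring. Both measured steps that end in compound 3 bear on the ring carried by that nitrogen, yet neither can be sized because of the limit of > 200000 nM in this assay, at which 3 of the 3 values shown sit. No direction and no size beyond the scatter can be read for the change to compound 4 from the measured steps alone; the expected step of a number no higher from compound 3 to compound 4 (the limit leaves the size open) is accordingly set at none beyond the scatter. Compound 4 is estimated to give 200000 nM in this assay, with an expected range of 100000 nM to 400000 nM. It is expected that compound 4, like the three measured compounds, will most likely be reported only as a limit.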

Compound 4, half-maximal cytotoxic concentration: > 200000 nM
Compound 4 ended at the assay's limit (the forecaster's own chance of this, stated with the estimate: 80%); the middle value lies on the limit itself.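

Within the data shown here, no step from compound 3 or compound 2 to compound 4 can be read in this assay, because the values are a limit of the assay and not numbers: the limit of > 200000 nM in this assay, at which 4 of the 4 values shown sit. The compounds shown leave open how compounds 1 to 4 truly rank in this assay, and whether any change on the ring-nitrogen aromatic group would give a readable value.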